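The source may report more compounds than this note shows. Statements on the series, on what has been measured and on what is new or still open speak of the compounds shown alone.

Compound 1 `COCCN(C)C(=O)[C@H](CC1CCCCC1)OC(=O)N[C@@H](C)CN1CC(C)(C)c2cc(F)ccc21`: 172 nM
Compound 2 `C[C@@H](CN1CC(C)(C)c2cc(F)ccc21)NC(=O)O[C@@H](CC1CCCCC1)C(=O)N1CCC1`: 217 nM

Both compounds were tested in an assay on isolated protein for inhibition of cathepsin S (Homo sapiens); a higher number here means a weaker inhibitor, a lower number a stronger inhibitor. Compound 2 gives the higher of the two numbers, but the step of a 1.3-fold higher number from compound 1 to compound 2 (0.10 log units; within the scatter) lies within the scatter, so the two compounds cannot be told apart on this evidence.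

Compound 3 `C[C@@H](CN1CC(C)(C)c2cc(F)ccc21)NC(=O)O[C@@H](CC1CCCCC1)C(=O)N1CCCCC1` has not yet been measured. It differs from compound 2 in one place: piperidin-1-yl in place of azetidin-1-yl on a carbonyl carbon. For the measured compounds named here, the only measured step that bears on this change is the one from compound 1 to compound 2, which also exchanges the group on that same carbonyl carbon and gave a 1.3-fold higher number from compound 1 to compound 2 (0.10 log units; within the scatter), a difference within the scatter. Since that exchange left the number essentially unchanged, a similar outcome is expected for compound 3, with no step beyond the scatter: a 1.0-fold higher number from compound 2 to compound 3 (0.01 log units; within the scatter). Compound 3 is therefore estimated at 220 nM, with a range from 90 nM to 550 nM.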

Compound 3, inhibition constant: 39 nM
For compound 3 the middle estimate is 5.6-fold (0.75 log units) above the measured one, outside the stated range (below it).
By their numbers in this assay, from the lowest: compound 3; then compounds 1 and 2 (each within the scatter of the next).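

In this assay, the group on this carbonyl carbon proves able to move the number: piperidin-1-yl in place of azetidin-1-yl gives a 5.6-fold lower number from compound 2 to compound 3 (0.75 log units; beyond the scatter) and this step lies beyond the scatter, unlike the earlier exchange on the same carbon. Piperidin-1-yl also separates from (2-methoxyethyl)(methyl)amino, with a 4.4-fold lower number from compound 1 to compound 3 (0.64 log units; beyond the scatter) and again a step beyond the scatter, so of the three groups shown only piperidin-1-yl stands apart. No evidence is available on what lies behind this difference.

The compounds shown leave open whether the number falls steadily with ring size, as pyrrolidin-1-yl, with its five-membered ring, is not among them. They also do not tell whether the lower number survives in a larger ring such as azepan-1-yl, or with an oxygen in the six-membered ring, as in morpholin-4-yl.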